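The compounds below may be only part of what the source reports. "The series", "measured", "known", "first", "only" and "open" are said of these compounds alone.

Working notes on the series.

Of the compounds shown here, two have numbers so far. Compound 1, `O=C1/C(=C\c2ccncc2)c2ccccc2N1Cc1ccccc1`, was run in a functional assay on HL-60 cells (Homo sapiens) for cytotoxicity, read by MTT assay, with a stated time of 72 h, tested at 0.5 uM (on this read-out higher numbers stand for a weaker effect at the one concentration tested and lower numbers for a stronger effect), and gives 101%. Compound 2, `CC(c1ccccc1)N1C(=O)/C(=C\c2cnc3ccccc3c2)c2ccccc21`, gives in this assay a value of 116%. On these two numbers compound 2 stands highest, and its nearest neighbour, compound 1, sits lower by a gap that is beyond the usual scatter. Neither number points to a strong effect at the single concentration used; both lie at or above the untreated level.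

Compound 3, `CC(c1ccccc1)N1C(=O)/C(=C/c2cnc3ccccc3c2)c2ccccc21`, is not yet measured. Set against compound 2 the difference is the two compounds have the same atoms and bonds; at least one stereo element is drawn with a configuration in one of them and without one in the other: 1 of 2 stereo elements differ; a double bond is drawn Z in compound 2 and E in compound 3, that is, a double bond is drawn Z in compound 2 and E in compound 3. Among the compounds with values here, no pair of measured compounds shows what such a change does in this assay, so nothing here gives the size of that step.

Because compound 2 already gives 116% and compound 1 gives 101%, both near the no-effect level, the expectation is that the step of a number 11 percentage points lower from compound 2 to compound 3 (beyond the scatter) stays within the scatter, with a slight lean downward. Compound 3 is therefore estimated at 105% in this assay, with a range from 85% to 125%.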

Compound 3, a percentage reported as activity, at one concentration (the size of the read-out at that concentration, not a potency): 110%
Beside the measured number, compound 3's estimate is 5 percentage points below it; the measured number falls inside the stated range.
By their numbers in this assay, from the lowest: compounds 1, 3 and 2 (each within the scatter of the next, the first and the last beyond it).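

In this assay the series now has its first step that differs in one place, and the double bond going from Z to E gives a number 6 percentage points lower from compound 2 to compound 3 (within the scatter). Within the data shown here, at this position, the geometry of the double bond therefore does not separate the two compounds at the single concentration tested, and neither form shows a strong effect, something the earlier compounds could not show. This reading carries one caveat about how the pair is drawn: the fact that one of compounds 2 and 3 is drawn with a defined configuration and the other without, at the place where they differ.

Going by these compounds, it remains open whether the same change in geometry would matter in a compound with a clear effect, and whether a different substituent on the shared core, such as a methoxy group, an amine or a carboxylic acid, would bring the read-out down at this concentration. Among these compounds, compound 1 differs from compound 2 in more than one place, so no step between them can be read, and the separate contributions of those places remain unknown.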